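The source may report more compounds than this note shows. Statements on the series, on what has been measured and on what is new or still open speak of the compounds shown alone.

Measured in an assay on CHO cells for agonist activity at 5-hydroxytryptamine receptor 1D (Homo sapiens), read by GTPgammaS binding; on this read-out higher numbers stand for an effect only at larger amounts of compound and lower numbers for an effect already at smaller amounts:
compound 1 `c1ccc(CNCC2CCN(CCCc3c[nH]c4ccc(-n5cnnc5)cc34)CC2)cc1` gives 5.6 nM
compound 2 `CN(Cc1cccs1)C1CCN(CCCc2c[nH]c3ccc(-n4cnnc4)cc23)CC1` gives 3.5 nM

Compound 2 stands together with compound 1 in this assay; the step of a 1.6-fold lower number from compound 1 to compound 2 (0.20 log units; within the scatter) lies within the scatter. Compound 3 `COC[C@H](NC1CCN(CCCc2c[nH]c3ccc(-n4cnnc4)cc23)CC1)c1ccccc1` differs from compound 2 by (2-methoxy-1-phenylethyl)amino in place of methyl((thiophen-2-yl)methyl)amino on a saturated ring carbon. For the measured compounds named here, the only measured step touching the amine on this ring carbon is a 1.6-fold lower number from compound 1 to compound 2 (0.20 log units; within the scatter), which gave no shift beyond the scatter. A step of similar size is therefore expected, a 1.4-fold higher number from compound 2 to compound 3 (0.15 log units; within the scatter), with no direction beyond the scatter. Compound 3 is estimated at 5 nM in this assay, between 1.5 nM and 20 nM.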

Compound 3, half-maximal effective concentration: 0.9 nM
Estimate against measurement, compound 3: 5.6-fold (0.74 log units) above; the whole stated range lies above it.
By their numbers in this assay, from the lowest: compound 3; then compounds 2 and 1 (each within the scatter of the next).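

In this assay, for the compounds shown here, the amine on this saturated ring carbon does move the read-out: (2-methoxy-1-phenylethyl)amino gives a 3.9-fold lower number from compound 2 to compound 3 (0.59 log units; beyond the scatter) and a 6.2-fold lower number from compound 1 to compound 3 (0.79 log units; beyond the scatter) as the first steps here beyond the scatter. From compound 2 to compound 3, a six-membered aromatic ring of carbon only replaces a five-membered aromatic ring with 1 hetero atom, while a hydrogen-bond donor and a defined stereocentre also enter, so these changes cannot be separated. Nothing measured bears on the cause of the step.

Open, going by these compounds, is whether the methoxy group matters, which (1-phenylethyl)amino on the same ring carbon would test. Also open, on these data alone, is how the opposite configuration at the stereocentre reads.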